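Removing a methyl from the ring carbon of compound 3

This account rests on a few compounds, and the source may have more. Where it says the series, first, only, none or still open, it means among the compounds named here.

Measured so far:
- compound 1, `CC/C=C/[C@H](CC)C[C@@]1(C)C[C@@H](CC)[C@@H](CC(=O)OC)OO1`: > 1000 nM in a functional assay on Microglia cells (Rattus norvegicus); on this read-out lower numbers stand for stronger inhibition and higher numbers for weaker inhibition
- compound 2, `CC/C=C/[C@H](CC)C/C(=C/[C@@]1(CC)C[C@H](CC)[C@H](CC(=O)O)OO1)CC`: > 10000 nM in this assay
- compound 3, `CC/C=C/[C@H](CC)C[C@]1(CC)C=C(CC)/C(=C/C(=O)OC)O1`: > 10000 nM in this assay

The value given for compound 1 is a limit of the assay and not a number, as shown by the limit of > 1000 nM in this assay, at which 1 of the 3 values shown sits. For compound 2 the value is also a limit, one of the two that the limit of > 10000 nM in this assay, at which 2 of the 3 values shown sit, describes. Compound 3 stands at that same limit, so no number is known for it and nothing can be said about how it ranks against compound 1 or compound 2 beyond the fact that none of the three gave a measurable inhibition.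

Compound 4, `CC/C=C/[C@H](CC)C[C@]1(C)C=C(CC)/C(=C/C(=O)OC)O1`, is yet to be measured in this assay. It differs from compound 3 in one place: hydrogen in place of methyl on a saturated chain carbon bound to a saturated ring carbon. For the measured compounds named here, since compound 3 itself gave only a limit, no step between measured compounds tells how such a change affects this assay, and a single methyl is a small change. The step that the limit leaves unreadable from compound 3 to compound 4 is therefore expected to be none beyond the scatter, with compound 4 most likely returning a limit as well. Compound 4 is estimated at 20000 nM, in the range 5000 nM to 100000 nM.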

Compound 4, half-maximal inhibitory concentration: > 10000 nM
Compound 4 was reported as a limit; the forecaster's own chance of this, stated with the estimate: 85%; the middle value is on the limit's open side.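

Compound 3 and compound 4 both stand at a limit of this assay and not at a number, so no step can be read between them: the limit of > 10000 nM in this assay, at which 3 of the 4 values shown sit.

The compounds shown leave open how strongly any of them inhibits, and so whether putting hydrogen in place of methyl at this spot changes inhibition at all.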